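The compounds below may be only part of what the source reports. "The series", "measured", "known", "first", "only" and "open" are said of these compounds alone.

Of the compounds shown here, three built on one shared core have been tested in an assay on isolated protein for inhibition of 2-Hydroxyacid oxidase 2 (Homo sapiens), tested at 1 uM; on this read-out higher numbers stand for a stronger effect at the one concentration tested and lower numbers for a weaker effect. Compound 1 `Cc1n[nH]c(C(=O)O)c1Cc1cccc(-c2cccc(F)c2)c1` gives 20%. Compound 2 `Cc1n[nH]c(C(=O)O)c1Cc1cccc(-c2ccc(OC(F)(F)F)cc2)c1` gives 6%, and compound 3 `Cc1n[nH]c(C(=O)O)c1Cc1ccc(C(N)=O)cc1` gives 0%. Among these three numbers compound 2 stands second highest. Its nearest neighbour is compound 3, whose number lies within the usual scatter of that of compound 2, so the two cannot be told apart on this read-out. Compound 1 is the furthest away, and its number lies beyond the scatter, higher than that of compound 2.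

Compound 4 `Cc1n[nH]c(C(=O)O)c1Cc1cccc(-c2ccc(C(F)(F)F)cc2)c1` has not yet been measured in this assay. It differs from compound 2 in one place: trifluoromethyl in place of trifluoromethoxy on an aromatic carbon. Going by the values given here, no two measured compounds differ in just this way, so the record contains no step of this kind to lean on; the change is small, one group of four heavy atoms replacing one of five heavy atoms, and the account therefore expects a step of a number 4 percentage points higher from compound 2 to compound 4 (within the scatter) in this assay, which is none beyond the scatter. For compound 4 the estimate in this assay is 10%, with a range from 0% to 25%, and the measured figure remains to be reported.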

Compound 4, a percentage reported as inhibition, at one concentration (the size of the read-out at that concentration, not a potency): 8%
Compound 4: middle estimate off by 2 percentage points, on the high side; low and high end bracket the measured number.
By their numbers in this assay, from the lowest: compounds 3, 2 and 4 (each within the scatter of the next); then compound 1.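

In this assay, going by these compounds alone, trifluoromethyl in place of trifluoromethoxy, on an aromatic carbon para to a large group, gives a number 2 percentage points higher from compound 2 to compound 4 (within the scatter); this is the first step in the record that changes one place only. At this position, the read-out therefore cannot tell the two groups apart, so removing the oxygen of trifluoromethoxy, with the hydrogen-bond acceptor counted for that group, brings no change that can be read here. No measurement is available that would explain this result.

Within the data shown here, compound 2 gives 6% and compound 4 gives 8% at the one concentration tested, so this step says nothing about potency and shows only that these two groups cannot be separated under these conditions. On these data alone, whether a group of another kind at this place, such as an amine, a carboxylic acid or a nitrile, would move the number beyond the scatter stays open, as does whether the same exchange would also leave the number unresolved on a compound with a higher starting value.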